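This account rests on a few compounds, and the source may have more. Where it says the series, first, only, none or still open, it means among the compounds named here.

Compound 2, `CNC(=O)c1cc(Oc2ccc(NC(=O)c3cc4cccnc4n(-c4ccc(Br)cc4)c3=O)cc2)ccn1`, is one of three analogues of a shared core that differ only in the substituent on the pendant aromatic ring. In a functional assay on A549 cells (Homo sapiens) for antiproliferative activity, read by MTT assay, with a stated time of 72 h (a lower number here means a stronger inhibitor, a higher number a weaker inhibitor), compound 2 gives 1050 nM. Compound 1, `CNC(=O)c1cc(Oc2ccc(NC(=O)c3cc4cccnc4n(-c4ccc(F)cc4)c3=O)cc2)ccn1`, gives 110 nM, and compound 3, `CNC(=O)c1cc(Oc2ccc(NC(=O)c3cc4cccnc4n(-c4ccc(OC)cc4)c3=O)cc2)ccn1`, gives 3110 nM. Compound 2 therefore holds the second highest of the three numbers: the nearest is compound 3, the step from compound 2 to compound 3 being a 3.0-fold higher number from compound 2 to compound 3 (0.47 log units; beyond the scatter), and the furthest is compound 1, the step from compound 1 to compound 2 being a 9.5-fold higher number from compound 1 to compound 2 (0.98 log units; beyond the scatter). The step from compound 1 to compound 3 is a 28-fold higher number from compound 1 to compound 3 (1.45 log units; beyond the scatter).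

Compound 4, `CCNC(=O)c1cc(Oc2ccc(NC(=O)c3cc4cccnc4n(-c4ccc(Br)cc4)c3=O)cc2)ccn1`, is not yet measured. It differs from compound 2 by methyl in place of hydrogen on a saturated chain carbon bound to an amide-type nitrogen. For the measured compounds named here, none of the measured steps touches this part of the molecule; all three concern the substituent on the aromatic ring, and the bromo group of compound 2 is kept in compound 4. Going by the values given here, there is thus no measured step that bears on this change, and no basis for expecting a step beyond the scatter in this assay in either direction. For compound 4 the estimated step from compound 2 is a 1.1-fold higher number from compound 2 to compound 4 (0.06 log units; within the scatter), so compound 4 is expected at 1200 nM, within a range from 400 nM to 3600 nM.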

Compound 4, half-maximal inhibitory concentration: 910 nM
Estimate against measurement, compound 4: 1.3-fold (0.12 log units) above, and the stated range covers the measured number.
By their numbers in this assay, from the lowest: compound 1; then compounds 4 and 2 (each within the scatter of the next); then compound 3.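

Replacing methylcarbamoyl with ethylcarbamoyl, with the bromo group kept, gives in this assay a 1.2-fold lower number from compound 2 to compound 4 (0.06 log units; within the scatter), the first step shown at this end of the molecule. The added methyl, on a saturated chain carbon bound to an amide-type nitrogen, thus produces no step beyond the scatter, unlike the earlier changes on the aromatic ring, which all lie beyond it, as with a 9.5-fold higher number from compound 1 to compound 2 (0.98 log units; beyond the scatter) and a 3.0-fold higher number from compound 2 to compound 3 (0.47 log units; beyond the scatter). No measurement is available that would explain this result in terms of how the compounds act in the cells.

The compounds shown leave open how far this tolerance extends, since a single added methyl says little about a longer chain such as propyl or butyl, a cyclopropyl ring, or a chain ending in an amine, a hydroxyl or a carboxylic acid. They also leave open whether ethylcarbamoyl would give the same result alongside the fluoro group of compound 1, which has the lowest number of the series, or the methoxy group of compound 3.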